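Moving the Chlorine on a Carbamate Antagonist Scaffold

The source may hold more compounds than are shown below. What is called first, only, known or untested is meant among the compounds shown, and "the series" means these compounds.

Compound 1 `Cc1c(C(C)OC(=O)NC2CCCCC2)oc2ncnn12` in a functional assay on CHO cells for antagonist activity at metabotropic glutamate receptor 5 (Homo sapiens), read by calcium flux (on this read-out lower numbers stand for stronger inhibition and higher numbers for weaker inhibition), gives 3160 nM.
Compound 2 `Cc1c(C(C)OC(=O)Nc2ccccc2Cl)oc2ncnn12` in this assay gives 501 nM.

Among these two, compound 2 shows the lower number, and its only neighbour is compound 1, separated by a 6.3-fold lower number from compound 1 to compound 2 (0.80 log units; beyond the scatter). Within the data shown here, that step exchanges a saturated ring for a chlorinated aromatic ring and is the single measured change available here.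

Compound 3 `Cc1c(C(C)OC(=O)Nc2cccc(Cl)c2)oc2ncnn12` is the next member: 3-chlorophenyl in place of 2-chlorophenyl on an amide-type nitrogen. The chlorine stays on the phenyl ring, so the whole of the earlier step is not repeated; only the placement of the same substituent shifts. Among the measured compounds shown here, no measured pair shows what such a shift does in this assay, so the expectation rests on the fact that both compound 2 and compound 3 keep the chlorophenyl carbamate that distinguished compound 2 from compound 1.

Compound 3 is therefore expected to land near compound 2, with a step of a 1.3-fold higher number from compound 2 to compound 3 (0.10 log units; within the scatter) that may fall within the scatter or be modest in either direction. The estimate for compound 3 in this assay is 630 nM, with a range from 160 nM to 2500 nM.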

Compound 3, half-maximal inhibitory concentration: 39.8 nM
For compound 3 the middle estimate is 16-fold (1.20 log units) above the measured one; measured number outside the range, below it.
By their numbers in this assay, from the lowest: compound 3; then compound 2; then compound 1.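

In this assay, the exchange of 2-chlorophenyl for 3-chlorophenyl on the amide-type nitrogen gives a 13-fold lower number from compound 2 to compound 3 (1.10 log units; beyond the scatter) and is a large step, although the group that leaves and the group that enters have the same heavy atoms and the same counts of donors and acceptors; the placement of the chlorine on the phenyl ring is therefore enough on its own to move the number well beyond the scatter. Set against the cyclohexyl group, 3-chlorophenyl gives a 79-fold lower number from compound 1 to compound 3 (1.90 log units; beyond the scatter) and compound 3 has the lowest number of the three, with its steps to both others beyond the scatter, so the earlier modest step from cyclohexyl to 2-chlorophenyl showed only part of what a chlorophenyl group can do at this nitrogen. Nothing available here says why the placement of the chlorine matters so much.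

The compounds shown leave open whether the step belongs to chlorine in particular, since unsubstituted phenyl and phenyl rings carrying methoxy, methyl or a nitrile in its place are not among them. They also leave open whether the same preference would hold if the carbamate were replaced by a urea or if the shared core were changed.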